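Heavier halogen on the fused ring: bromo to iodo

This account rests on a few compounds, and the source may have more. Where it says the series, first, only, none or still open, it means among the compounds named here.

Measured so far:
Compound 1 `CC(C)(C)c1cc(NC(=O)Nc2ccc(-c3cn4cc(F)ccc4n3)cc2)no1` gives 20.9 nM in a functional assay on MV4-11 cells (Homo sapiens) for cytotoxicity, read by MTT assay, with a stated time of 72 h; a higher number here means a weaker inhibitor, a lower number a stronger inhibitor.
Compound 2 `CC(C)(C)c1cc(NC(=O)Nc2ccc(-c3cn4cc(Cl)ccc4n3)cc2)no1` gives 24.8 nM.
Compound 3 `CC(C)(C)c1cc(NC(=O)Nc2ccc(-c3cn4cc(Br)ccc4n3)cc2)no1` gives 44.5 nM.

Compound 3 carries the highest number of the three. Against compound 1 the step is a 2.1-fold higher number from compound 1 to compound 3 (0.33 log units; beyond the scatter); against compound 2 it is a 1.8-fold higher number from compound 2 to compound 3 (0.25 log units; within the scatter).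

Compound 4 `CC(C)(C)c1cc(NC(=O)Nc2ccc(-c3cn4cc(I)ccc4n3)cc2)no1` differs from compound 3 by iodo in place of bromo on an aromatic carbon. Each earlier halogen swap on this carbon moved the number only slightly upward: a 1.2-fold higher number from compound 1 to compound 2 (0.07 log units; within the scatter), then a 1.8-fold higher number from compound 2 to compound 3 (0.25 log units; within the scatter). A similar small step upward in this assay is therefore expected for compound 4, a 1.5-fold higher number from compound 3 to compound 4 (0.16 log units; within the scatter). The estimate for compound 4 is 65 nM, with a range from 28 nM to 150 nM.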

Compound 4, half-maximal inhibitory concentration: 98.6 nM
Compound 4: the middle estimate sits 1.5-fold (0.18 log units) below what was measured; measured number inside the range.
By their numbers in this assay, from the lowest: compounds 1, 2 and 3 (each within the scatter of the next, the first and the last beyond it); then compound 4.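

Going on to iodo gives a 2.2-fold higher number from compound 3 to compound 4 (0.35 log units; beyond the scatter), the first swap between neighbouring halogens on this carbon that lies beyond the scatter in this assay. The gaps to the two lighter halogens are wider still, with a 4.0-fold higher number from compound 2 to compound 4 (0.60 log units; beyond the scatter) and a 4.7-fold higher number from compound 1 to compound 4 (0.67 log units; beyond the scatter). Iodo therefore gives the weakest inhibitor of these four compounds, while a halogen swap at this position is not always a small change.

Nothing available here says what lies behind this loss. On these data alone, whether a methoxy group, a nitrile or an amine on this carbon would keep the number as low as fluoro does stays open.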